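The source may hold more compounds than are shown below. What is called first, only, known or untested is meant among the compounds shown, and "the series" means these compounds.

Within the data shown here, in a functional assay on T47D cells (Homo sapiens) for inhibition (on this read-out lower numbers stand for stronger inhibition of growth and higher numbers for weaker inhibition of growth), compound 1 `COc1cc(/C=C/C(=O)c2cccc(-n3cc(-c4ccc(Cl)cc4)[nH]c3=O)c2)cc(OC)c1OC` gives 6650 nM, the higher of the two numbers known so far. Compound 2 `COc1cc(/C=C/C(=O)c2cccc(-n3cc(-c4ccccc4)[nH]c3=O)c2)ccc1O` gives 2700 nM, a gap beyond the scatter, although the two structures differ in more than one place. Compound 3 `COc1cc(/C=C/C(=O)c2cccc(-n3cc(-c4cc(OC)c(OC)c(OC)c4)[nH]c3=O)c2)cc(OC)c1OC` has 3,4,5-trimethoxyphenyl in place of 4-chlorophenyl on an aromatic carbon of compound 1: 3,4,5-trimethoxyphenyl in place of 4-chlorophenyl on an aromatic carbon. Among the measured compounds shown here, no measured step isolates this change, so no shift beyond the scatter is expected, and the estimated step is a 1.5-fold lower number from compound 1 to compound 3 (0.17 log units; within the scatter). For compound 3 the expected value is 4500 nM, with an estimated range of 1400 nM to 14000 nM.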

Compound 3, concentration for 50% growth inhibition: 3080 nM
Beside the measured number, compound 3's estimate is 1.5-fold (0.16 log units) above it; measured number inside the range.
By their numbers in this assay, from the lowest: compounds 2 and 3 (each within the scatter of the next); then compound 1.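

In this assay, among these compounds, putting 3,4,5-trimethoxyphenyl in place of 4-chlorophenyl on this aromatic carbon gives a 2.2-fold lower number from compound 1 to compound 3 (0.33 log units; beyond the scatter) and is the first change in a single place that can be read. It shows that the number responds to the group at this position, though only modestly, and that the larger group with its three methoxy substituents does not weaken growth inhibition. No evidence at hand accounts for this step. Which of the methoxy groups matters remains open, as does how an amine or a carboxylic acid on this phenyl ring would read.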